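A few compounds are considered here, and "the series" means these few. Any claim that something is new, unique, unknown or untested is made for them only; others in the source may bear on it.

Measured compounds:
Compound 1 `CC(C)NC1=NS(=O)(=O)c2cc(Cl)ccc2N1`: 36.3 uM
Compound 2 `CC(C)NC1=NS(=O)(=O)c2cc(F)ccc2N1`: 43.1 uM
Compound 3 `O=S1(=O)NC(NC2CC2)=Nc2ccc(F)cc21`: > 300 uM (a limit)

In a functional assay (aorta) with Rattus norvegicus as the target (on this read-out lower numbers stand for an effect already at smaller amounts and higher numbers for an effect only at larger amounts of compound), compound 1 gives 36.3 uM, level with compound 2 at 43.1 uM. The measured step between them is a 1.2-fold higher number from compound 1 to compound 2 (0.07 log units; within the scatter), so swapping the halogen leaves the number within the scatter. Compound 3 gives > 300 uM, which is a limit of the assay and not a number.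

Compound 4 `CCC(C)NC1=NS(=O)(=O)c2cc(Cl)ccc2N1` keeps the core of compound 1 and changes only the amine side chain: methyl in place of hydrogen on a saturated chain carbon, two bonds along the chain from an amine nitrogen. A methyl takes the place of a hydrogen on a saturated chain carbon, two bonds along the chain from an amine nitrogen, turning isopropyl into sec-butyl. Among the compounds with values here, no measured step makes this exact change. Within the data shown here, the only numbered step, a 1.2-fold higher number from compound 1 to compound 2 (0.07 log units; within the scatter), lies elsewhere on the molecule and offers only a weak guide. A small change is therefore expected, with no clear direction beyond the scatter. The expected step is a 1.2-fold lower number from compound 1 to compound 4 (0.08 log units; within the scatter). For compound 4 the estimated value is 30 uM, with an expected range from 10 uM to 90 uM.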

Compound 4, concentration for half-maximal effect: 15.5 uM
For compound 4 the middle estimate is 1.9-fold (0.29 log units) above the measured one; the range from low to high includes it.
By their numbers in this assay, from the lowest: compound 4; then compounds 1 and 2 (each within the scatter of the next). At a limit, above all of these: compound 3.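

Before this result, the only step with a number was the halogen swap, which stayed within the scatter, so no single change had yet been seen to move the number in this assay at all. Turning isopropyl into sec-butyl gives a 2.3-fold lower number from compound 1 to compound 4 (0.37 log units; beyond the scatter) and is the first step here that lies beyond the scatter, though only a modest one. The amine side chain is therefore a place where one added methyl can be read, and in this single pair the lower number comes with the larger chain.

On these data alone, whether a longer chain such as n-pentyl or a ring such as cyclohexyl on the amine would lower the number further or raise it stays open, as does whether compound 2 would answer the same methyl in the same way. Nothing measured here gives a cause for the step.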